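A Single Stereocentre Inverted at the Assay Limit

The source may report more compounds than this note shows. Statements on the series, on what has been measured and on what is new or still open speak of the compounds shown alone.

Of the compounds shown here, three have been tested so far in a functional assay on Vero cells (Chlorocebus sabaeus) for cytotoxicity (on this read-out higher numbers stand for weaker inhibition and lower numbers for stronger inhibition), and none of them has yielded a number. Compound 1 (`Nc1ccn([C@@H]2CC(F)(F)[C@H](CO)O2)c(=O)n1`) gives > 100000 nM, which is a limit of the assay. Compound 2 (`O=c1ccn([C@H]2C=C(F)[C@H](CO)O2)c(=O)[nH]1`) gives > 100000 nM, again a limit. Compound 3 (`Nc1ncnc2c1ncn2[C@@H]1CC(F)(F)[C@H](CO)O1`) gives > 100000 nM, also a limit and not a number. The whole picture to date is therefore (the limit of > 100000 nM in this assay, at which 3 of the 3 values shown sit), and compound 3 shares that position with the other two compounds.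

The next compound, compound 4 (`Nc1ncnc2c1ncn2[C@H]1CC(F)(F)[C@H](CO)O1`), has not yet been measured and is closely related to compound 3: the two compounds have the same atoms and bonds and differ only in configuration as drawn: 1 of 2 stereo elements differ; a stereocentre at a saturated ring carbon is drawn S in compound 3 and R in compound 4. Going by the values given here, no measured pair differs in one place only, so the size of such an inversion has not been observed in this assay. The expectation rests on (the limit of > 100000 nM in this assay, at which 3 of the 3 values shown sit), and no clear direction can be drawn from it. The estimated a number no higher from compound 3 to compound 4 (the limit leaves the size open) is expected to stay within the usual scatter, with the assay most likely reporting only a limit again. For compound 4 the estimated value is 100000 nM, with an expected range from 50000 nM to 200000 nM.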

Compound 4, half-maximal inhibitory concentration: > 100000 nM
Compound 4 ended at the assay's limit; the forecaster's own chance of this, stated with the estimate: 88%; the middle value sits exactly at the limit.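

In this assay compound 4 gives > 100000 nM, which is a limit of the assay and not a number. Compound 3 sits at the same limit, so no step can be read between compound 3 and compound 4. The compounds shown leave open whether inverting this stereocentre changes the read-out at all: the limit of > 100000 nM in this assay, at which 4 of the 4 values shown sit.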